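Benzoyl aryl swaps in a trimethoxyphenyl triazolothiadiazine series

The source may report more compounds than this note shows. Statements on the series, on what has been measured and on what is new or still open speak of the compounds shown alone.

Measured compounds:
compound 1 `COc1cc(-c2nnc3n2NC(c2cccs2)C(C(=O)c2ccc(C)cc2)S3)cc(OC)c1OC`: 12700 nM
compound 2 `COc1cc(-c2nnc3n2NC(c2ccco2)C(C(=O)c2ccc(-c4ccccc4)cc2)S3)cc(OC)c1OC`: > 100000 nM
compound 3 `COc1cc(C(=O)C2Sc3nnc(-c4cc(OC)c(OC)c(OC)c4)n3NC2c2cccs2)cc(OC)c1OC`: > 100000 nM

In a functional assay on A549 cells (Homo sapiens) for cytotoxicity, read by MTT assay, with a stated time of 48 h (on this read-out higher numbers stand for weaker inhibition and lower numbers for stronger inhibition), compound 1 gives 12700 nM. For compound 2 the assay reports only a limit, > 100000 nM. For compound 3 likewise only a limit is reported, > 100000 nM. Compound 2 therefore stands at the weak end of the numbers shown, together with compound 3 at the limit of > 100000 nM in this assay, at which 2 of the 3 values shown sit.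

Compound 4 `COc1cc(-c2nnc3n2NC(c2ccco2)C(C(=O)c2ccc([N+](=O)[O-])cc2)S3)cc(OC)c1OC` is not yet measured. It differs from compound 2 at the aryl on the carbonyl carbon: nitro in place of phenyl on an aromatic carbon

Within the data shown here, the only step measured so far that touches this part of the molecule is the change on the carbonyl carbon, an at least 7.8-fold higher number from compound 1 to compound 3 (0.89 log units; beyond the scatter), which ends at the limit. Nothing measured shows what a nitro group does here. Since compound 2 is itself a limit, no direction beyond the scatter can be expected with any confidence; a weak value near the limit, with an estimated step of an at least 1.2-fold lower number from compound 2 to compound 4 (0.09 log units; that floor lies within the scatter), seems most likely. Compound 4 is estimated at 80000 nM, with a range from 20000 nM to 200000 nM.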

Compound 4, half-maximal inhibitory concentration: > 100000 nM
Compound 4: a limit, no number; the forecaster's own chance of this, stated with the estimate: 55%; middle value at least 1.2-fold (0.09 log units) away from the limit.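

Compound 2 and compound 4 are both reported only as limits, so the change from phenyl to nitro gives no readable step: the limit of > 100000 nM in this assay, at which 3 of the 4 values shown sit.

Still open, going by these compounds, is whether 4-phenylphenyl and 4-nitrophenyl on the carbonyl carbon differ at all in this assay.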